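A Fourth Amide in a Series Held at the Limit

The compounds below may be only part of what the source reports. "The series", "measured", "known", "first", "only" and "open" are said of these compounds alone.

Compound 1, `CS(=O)(=O)c1ccc(C(=O)NCC(=O)N2CCCCC2)cc1[N+](=O)[O-]`, gives > 60000 nM in an assay on isolated protein for inhibition of vitamin D3 receptor (Homo sapiens), read by fluorescence polarization (a higher number here means a weaker inhibitor, a lower number a stronger inhibitor), a limit of the assay and not a number.
Compound 2, `CC(C)N(C(=O)CNC(=O)c1ccc(S(C)(=O)=O)c([N+](=O)[O-])c1)C(C)C`, gives > 60000 nM in this assay, again a limit.
Compound 3, `CN(Cc1ccccc1)C(=O)CNC(=O)c1ccc(S(C)(=O)=O)c([N+](=O)[O-])c1`, gives > 60000 nM in this assay, also a limit.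

Compound 3 therefore stands where the other two stand, at the limit of this assay: the limit of > 60000 nM in this assay, at which 3 of the 3 values shown sit. As far as these compounds go, the steps among the three amides, a step that the two limits leave unreadable from compound 1 to compound 2, a step that the two limits leave unreadable from compound 1 to compound 3 and a step that the two limits leave unreadable from compound 2 to compound 3, are each left unreadable by the two limits, so their size and direction are unknown. None of the three amide groups on the carbonyl carbon has brought a measurable value.

Compound 4, `CN1CCN(C(=O)CNC(=O)c2ccc(S(C)(=O)=O)c([N+](=O)[O-])c2)CC1`, carries a change at that same carbonyl carbon: 4-methylpiperazin-1-yl in place of benzyl(methyl)amino on a carbonyl carbon. The measured steps bearing on this change are the three unreadable ones, and all of them rest on values at the limit. There is no ground in the shown values for expecting a change in this assay beyond the scatter. Compound 4 is accordingly expected to sit at about 80000 nM, with a range from 30000 nM to 300000 nM, most probably reported again as a limit. The estimated step that the limit leaves unreadable from compound 3 to compound 4 is expected to be no more than the scatter allows.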

Compound 4, half-maximal inhibitory concentration: > 60000 nM
Compound 4 was reported as a limit; the forecaster's own chance of this, stated with the estimate: 90%; the middle value is on the limit's open side.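

Compound 4 is also reported as a limit in this assay, so the steps to it from compound 1, compound 2 and compound 3 cannot be read: the limit of > 60000 nM in this assay, at which 4 of the 4 values shown sit. The compounds shown leave open whether any amide group on this carbonyl carbon gives a measurable value in this assay, and how large these steps are or which way they run.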